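From a Bulky Ester to a Nitrile on the Shared Core

The compounds below may be only part of what the source reports. "The series", "measured", "known", "first", "only" and "open" are said of these compounds alone.

Compound 1 `COc1ccc2c(c1)OC(c1cc(OC)c(OC)c(OC)c1)C(C(=O)OC(C)C)=C2` gives 11800 nM in a functional assay for inhibition of nuclear factor NF-kappa-B complex (Homo sapiens); on this read-out lower numbers stand for stronger inhibition and higher numbers for weaker inhibition.
Compound 2 `COc1ccc2c(c1)OC(c1cc(OC)c(OC)c(OC)c1)C(C(=O)O)=C2` gives in this assay only a limit, > 50000 nM.
Compound 3 `COc1ccc2c(c1)OC(c1cc(OC)c(OC)c(OC)c1)C(C(=O)OC(C)(C)C)=C2` gives 14100 nM in this assay.

Among the two numbers actually reported, compound 3 carries the higher one, but its nearest neighbour is compound 1, and that gap is within the scatter: a 1.2-fold higher number from compound 1 to compound 3 (0.08 log units; within the scatter). For compound 2 the read-out reaches only (the limit of > 50000 nM in this assay, at which 1 of the 3 values shown sits), so it stands as a limit rather than a number. an at least 4.2-fold higher number from compound 1 to compound 2 (0.62 log units; beyond the scatter). an at least 3.5-fold lower number from compound 2 to compound 3 (0.54 log units; beyond the scatter). Taken together, exchanging one alkyl group for another on the ester oxygen changes little, while removing the alkyl group altogether weakens inhibition beyond the scatter.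

Compound 4 `COc1ccc2c(c1)OC(c1cc(OC)c(OC)c(OC)c1)C(C#N)=C2` differs from compound 3 in one place: cyano in place of tert-butoxycarbonyl on a double-bonded ring carbon. Within the data shown here, none of the measured steps replaces the whole ester, so the closest guide is that the ester carbonyl and its oxygen have tolerated changes only at the alkyl end. A small change to the whole group is expected to cost some inhibition, with the value possibly reported only as a limit. Compound 4 is therefore expected to give about 22000 nM, with an estimated range from 7000 nM to 60000 nM. The step this estimate implies, a 1.6-fold higher number from compound 3 to compound 4 (0.19 log units; within the scatter), is expected to be a modest weakening.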

Compound 4, half-maximal inhibitory concentration: 3400 nM
The estimate for compound 4 lay 6.5-fold (0.81 log units) above the measured number; the measured number lies below the stated range.
By their numbers in this assay, from the lowest: compound 4; then compounds 1 and 3 (each within the scatter of the next). At a limit, above all of these: compound 2.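

Until now only the alkyl end of the ester had changed, so nothing showed whether the ester itself was needed at this double-bonded ring carbon. In this assay, cyano, which has no carbonyl and fewer heavy atoms, replaces the whole ester and gives a 4.1-fold lower number from compound 3 to compound 4 (0.62 log units; beyond the scatter) and a 3.5-fold lower number from compound 1 to compound 4 (0.54 log units; beyond the scatter), so among the compounds shown, an ester carbonyl is not required for inhibition and the best number belongs to the nitrile. Cyano in place of carboxy gives the widest gap, an at least 14-fold lower number from compound 2 to compound 4 (1.16 log units; beyond the scatter), but this step starts from compound 2, which stands only as a limit and not as a number: the limit of > 50000 nM in this assay, at which 1 of the 4 values shown sits.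

The compounds shown leave open whether the gain belongs to the nitrile itself or simply to the loss of the ester, a question that a primary amide, a methyl ketone or a plain methyl group on this carbon would help to settle. They also leave open whether the nitrile keeps its advantage when the methoxy groups on the shared core are exchanged for other groups, such as a hydroxyl or a chlorine.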